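The source may hold more compounds than are shown below. What is called first, only, known or untested is meant among the compounds shown, and "the series" means these compounds.

Measured so far in a functional assay on MCF7 cells (Homo sapiens) for antiproliferative activity, read by sulforhodamine B assay, with a stated time of 48 h; a higher number here means a weaker inhibitor, a lower number a stronger inhibitor:
- compound 1 `COc1cccc(/C=C/C(=O)C(=Cc2ccc(OC)c(OC)c2OC)C(=O)/C=C/c2cccc(OC)c2OC)c1OC`: 380 nM
- compound 2 `COc1ccc(/C=C/C(=O)C(=Cc2ccc(O)c(OC)c2)C(=O)/C=C/c2ccc(OC)cc2OC)c(OC)c1`: 2140 nM

Of these two, compound 2 has the higher number, at 2140 nM, so it is the weaker inhibitor. Its nearest neighbour, compound 1, lies at 380 nM, a gap beyond the usual scatter. The two differ in more than one place, so this gap cannot be read as the effect of any single change.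

Next is compound 3 `COc1ccc(/C=C/C(=O)C(=Cc2cc(Br)c(O)c(OC)c2)C(=O)/C=C/c2ccc(OC)cc2OC)c(OC)c1`, which differs from compound 2 in one place: bromo in place of hydrogen on an aromatic carbon. This is bromo in place of hydrogen on an aromatic carbon, ortho to a hydroxy group, turning 4-hydroxy-3-methoxyphenyl into 3-bromo-4-hydroxy-5-methoxyphenyl.

Among the measured compounds shown here, the series offers no measured step between compounds that differ in one place, so any expectation here is weakly founded. In this assay, a small move towards a lower number is expected, probably not beyond the scatter. The estimated step is a 1.6-fold lower number from compound 2 to compound 3 (0.22 log units; within the scatter). For compound 3 the expected value is 1300 nM, with an estimated range of 450 nM to 3800 nM.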

Compound 3, half-maximal inhibitory concentration: 2600 nM
The estimate for compound 3 lay 2.0-fold (0.30 log units) below the measured number; measured number inside the range.
By their numbers in this assay, from the lowest: compound 1; then compounds 2 and 3 (each within the scatter of the next).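

In this assay, bromo in place of hydrogen on an aromatic carbon, ortho to a hydroxy group, gives a 1.2-fold higher number from compound 2 to compound 3 (0.08 log units; within the scatter), so 4-hydroxy-3-methoxyphenyl and 3-bromo-4-hydroxy-5-methoxyphenyl cannot be told apart on this read-out. Among the compounds shown here, this is the only comparison so far that isolates one place, and it shows that this aromatic carbon carries a bromine atom with no step that stands clear of the scatter. No measured property of these compounds bears on this result.

Still open, as far as these compounds go, is whether this tolerance belongs to bromo alone or extends to other groups on the same carbon, such as chloro, an amine, a carboxylic acid or a longer chain. Also open, from the compounds shown here alone, is what sets compound 1 at 380 nM, since it differs from the other compounds in more than one place and no single change can yet be tied to its number.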